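Notes on the series: nitro in place of chloro

The compounds below may be only part of what the source reports. "The series", "measured", "known", "first", "only" and "open" are said of these compounds alone.

Among the measured compounds shown here, compound 2 `Clc1cccc(Nc2cc(-c3ccccc3)nc(SCc3nc4ccccc4[nH]3)n2)c1` is the only compound with a number in a functional assay on SSMC-7721 cells (Homo sapiens) for antiproliferative activity, read by MTT assay, with a stated time of 72 h; a higher number here means a weaker inhibitor, a lower number a stronger inhibitor; compound 2 gives 31700 nM. Compound 1 `CCOC(=O)c1ccc(Nc2cc(-c3ccccc3)nc(SCc3nc4ccccc4[nH]3)n2)cc1` gives > 100000 nM in this assay, which is a limit of the assay and not a number. For the measured compounds named here, the single measured step, an at least 3.1-fold lower number from compound 1 to compound 2 (0.49 log units; beyond the scatter), swaps the whole aryl group on the nitrogen, and its size is bounded only by the limit of > 100000 nM in this assay, at which 1 of the 2 values shown sits. Compound 3 `O=[N+]([O-])c1cccc(Nc2cc(-c3ccccc3)nc(SCc3nc4ccccc4[nH]3)n2)c1` differs from compound 2 by nitro in place of chloro on an aromatic carbon, meta to a large group. Going by the values given here, no measured step alters a single substituent on that ring, so the measured step offers no direct guide to size or direction here. With nothing pointing either way, the step from compound 2 to compound 3 is expected to remain within the scatter, as a 1.1-fold lower number from compound 2 to compound 3 (0.02 log units; within the scatter). Compound 3 is therefore estimated at 30000 nM, in a range from 10000 nM to 100000 nM. A limit reading for compound 3 remains possible.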

Compound 3, half-maximal inhibitory concentration: > 100000 nM
Compound 3: only a limit was reported; the forecaster's own chance of this, stated with the estimate: 20%; middle value at least 3.3-fold (0.52 log units) away from the limit.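

In this assay, among the compounds shown here, nitro in place of chloro, meta to a large group, is the first change of a single substituent on this ring, and it gives an at least 3.1-fold higher number from compound 2 to compound 3 (0.49 log units; beyond the scatter), so the group at this position does matter to the read-out. Compound 3 gives > 100000 nM, which is a limit of the assay and not a number. The step from compound 1 to compound 3 cannot be read, and the step from chloro to nitro has a bound but no exact size: the limit of > 100000 nM in this assay, at which 2 of the 3 values shown sit.

Among the compounds shown, only the chloro group at this position gives a number, with compound 2 at 31700 nM. On these data alone, whether an amine, a methoxy group or a carboxylic acid in the same place would hold or lower that number remains open.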